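A few compounds are considered here, and "the series" means these few. Any claim that something is new, unique, unknown or untested is made for them only; others in the source may bear on it.

Of the compounds shown here, three have numbers so far in a functional assay on DU-145 cells (Homo sapiens) for antiproliferative activity, read by MTT assay, with a stated time of 48 h; on this read-out lower numbers stand for stronger inhibition and higher numbers for weaker inhibition. Compound 1 `COc1ccc(-c2nnc(-c3cn4ccccc4n3)o2)cc1` gives 12900 nM, compound 2 `Cc1cccn2cc(-c3nnc(-c4ccccc4)o3)nc12` gives 21800 nM, and compound 3 `Cc1cccn2cc(-c3nnc(-c4ccc(Br)cc4)o3)nc12` gives 38900 nM. Among the measured compounds shown here, the number for compound 3 stands higher than the one for compound 1, a gap beyond the usual scatter of repeated measurements, but it cannot be told apart from the number for compound 2.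

Compound 4 `COc1ccc(-c2nnc(-c3cn4cccc(C)c4n3)o2)cc1` has not yet been measured. It differs from compound 3 by methoxy in place of bromo on an aromatic carbon, para to a large group: methoxy in place of bromo on an aromatic carbon.

For the measured compounds named here, the one measured step at this carbon is a 1.8-fold higher number from compound 2 to compound 3 (0.25 log units; within the scatter). Putting bromo there in place of hydrogen therefore made no change that can be separated from noise, which gives little reason to expect a large shift when bromo leaves. Compound 1 also carries the methoxy group, on a core of its own, and its 12900 nM gives a weak pull toward a lower number. A small move in that direction is expected, one that may not clear the scatter, and the expected change is a 1.9-fold lower number from compound 3 to compound 4 (0.29 log units; within the scatter). For compound 4 the estimated value is 20000 nM, with an expected range from 9000 nM to 42000 nM.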

Compound 4, half-maximal inhibitory concentration: 10800 nM
The estimate for compound 4 lay 1.9-fold (0.27 log units) above the measured number, within the range that was stated.
By their numbers in this assay, from the lowest: compounds 4, 1, 2 and 3 (each within the scatter of the next, the first and the last beyond it).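

In this assay this aromatic carbon turns out to respond to the group it carries: methoxy in place of bromo gives a 3.6-fold lower number from compound 3 to compound 4 (0.56 log units; beyond the scatter) and so clears the scatter, which the earlier change of hydrogen to bromo, with a 1.8-fold higher number from compound 2 to compound 3 (0.25 log units; within the scatter) within the scatter, did not do. The comparison with hydrogen on the same core gives a 2.0-fold lower number from compound 2 to compound 4 (0.31 log units; beyond the scatter) and also lies beyond the scatter, so the modest shift is not only a matter of bromo leaving, since methoxy stands apart from hydrogen as well. The methyl group on the core, by contrast, makes no difference that can be separated from noise when methoxy is present, with a 1.2-fold lower number from compound 1 to compound 4 (0.08 log units; within the scatter) within the scatter, so these two methoxy compounds cannot be told apart.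

Nothing at hand explains why methoxy and bromo differ at this carbon. As far as these compounds go, how an amine, a hydroxy group or a longer chain such as ethoxy would compare at this same carbon remains open, as does whether the methoxy step would hold on any other cell line.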